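Swapping the five-membered ring on the amide carbonyl

The compounds below may be only part of what the source reports. "The series", "measured", "known", "first", "only" and "open" are said of these compounds alone.

Compound 1 `COc1cc2c(Oc3ccc(NC(=O)c4nc(-c5ccc(F)cc5)no4)cc3)ccnc2cc1OCCCN1CCC(C)CC1` gives 6380 nM in a functional assay on HT-29 cells (Homo sapiens) for antiproliferative activity, read by MTT assay, with a stated time of 72 h; a higher number here means a weaker inhibitor, a lower number a stronger inhibitor.
Compound 2 `COc1cc2nccc(Oc3ccc(NC(=O)c4nnc(-c5ccc(F)cc5)o4)cc3)c2cc1OC` gives 52300 nM in this assay.
Compound 3 `COc1cc2nccc(Oc3ccc(NC(=O)c4cc(-c5ccc(F)cc5)on4)cc3)c2cc1OC` gives only a limit, > 100000 nM, in this assay.

Compound 3 therefore has no firm number in this assay; what is known is that it sits at the limit of > 100000 nM in this assay, at which 1 of the 3 values shown sits, so it stands at the weak end of the three. Among the measured compounds shown here, the one measured step that reaches it, an at least 1.9-fold higher number from compound 2 to compound 3 (0.28 log units; that floor lies within the scatter), is itself only a floor. Compound 4 `COc1cc2nccc(Oc3ccc(NC(=O)c4nc(-c5ccc(F)cc5)no4)cc3)c2cc1OC` differs from compound 3 in one place: 3-(4-fluorophenyl)-1,2,4-oxadiazol-5-yl in place of 5-(4-fluorophenyl)-1,2-oxazol-3-yl on a carbonyl carbon. For the measured compounds named here, no measured step covers exactly this ring swap on this core. Compound 1 carries the same entering ring on a different side chain and gives a stronger number than compound 2 or compound 3, but the two changes are not separable here. The expectation is that compound 4 moves toward a stronger number than compound 3, an estimated step of an at least 3.3-fold lower number from compound 3 to compound 4 (0.52 log units; beyond the scatter). Compound 4 is expected to give about 30000 nM in this assay, between 8000 nM and 110000 nM.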

Compound 4, half-maximal inhibitory concentration: 39700 nM
Compound 4: the middle estimate sits 1.3-fold (0.12 log units) below what was measured; the measured number falls inside the stated range.
By their numbers in this assay, from the lowest: compound 1; then compounds 4 and 2 (each within the scatter of the next). At a limit, above all of these: compound 3.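

On the shared core, 3-(4-fluorophenyl)-1,2,4-oxadiazol-5-yl in place of 5-(4-fluorophenyl)-1,2-oxazol-3-yl gives an at least 2.5-fold lower number from compound 3 to compound 4 (0.40 log units; beyond the scatter) in this assay, so this ring swap does register. The choice between the two oxadiazole rings does not register, with a 1.3-fold lower number from compound 2 to compound 4 (0.12 log units; within the scatter). With the ring now the same, the side chain can be read alone, and a 6.2-fold higher number from compound 1 to compound 4 (0.79 log units; beyond the scatter) ties the stronger number of compound 1 to its 2-(4-methylpiperidin-1-yl)ethyl group rather than to the ring.

Compound 3 has only a limit, so the full size of its step stays open: the limit of > 100000 nM in this assay, at which 1 of the 4 values shown sits.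

Also open, from the compounds shown here alone, is whether a morpholine in place of the methylpiperidine, or a longer chain, would give a still lower number, and whether the ring of compound 2 would gain as much from the same side chain.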